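Replacing 4-bromophenyl with 4-methoxyphenyl: working notes

The source may hold more compounds than are shown below. What is called first, only, known or untested is meant among the compounds shown, and "the series" means these compounds.

In a functional assay on NCI-H460 cells (Homo sapiens) for inhibition, read by sulforhodamine B assay, with a stated time of 48 h (a lower number here means a stronger inhibitor of growth, a higher number a weaker inhibitor of growth), compound 1 `CCOC(=O)c1nn(-c2ccccc2)c(-c2ccc(OC)cc2)c1CNC(C)(C)C` gives 119000 nM; 148000 nM (2 entries) and compound 2 `CC(C)(C)NCc1c(C(=O)O)nn(-c2ccccc2)c1-c1ccc(Cl)cc1` gives 70500 nM as measured numbers. Compound 3 `CC(C)(C)NCc1c(C(=O)O)nn(-c2ccccc2)c1-c1ccc(Br)cc1` gives > 585000 nM as a limit and not a number.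

Compound 4 `COc1ccc(-c2c(CNC(C)(C)C)c(C(=O)O)nn2-c2ccccc2)cc1` follows from compound 3 through the change methoxy in place of bromo on an aromatic carbon with methoxy in place of bromo on an aromatic carbon, so that 4-bromophenyl becomes 4-methoxyphenyl. Among the measured compounds shown here, the only measured step at this place is an at least 8.2-fold higher number from compound 2 to compound 3 (0.91 log units; beyond the scatter) and lies beyond the scatter, so the group there can shift the number in this assay by a clear margin. Compound 1 also carries 4-methoxyphenyl, and its 119000 nM; 148000 nM (2 entries) is the closest guide, although it differs from compound 4 elsewhere.

On these data alone, a lower number is expected, with an estimated change of an at least 3.2-fold lower number from compound 3 to compound 4 (0.51 log units; beyond the scatter) whose true size stays open while only a limit stands at its start. For compound 4 the expected value is 180000 nM within an estimated range of 60000 nM to 600000 nM in this assay, and a further limit remains possible.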

Compound 4, concentration for 50% growth inhibition: > 659000 nM
Compound 4 ended at the assay's limit; the forecaster's own chance of this, stated with the estimate: 30%; middle value at least 3.6-fold (0.56 log units) away from the limit.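

In this assay, methoxy in place of chloro gives an at least 9.3-fold higher number from compound 2 to compound 4 (0.97 log units; beyond the scatter), so at this place on the aromatic carbon the chloro of compound 2 now stands apart from two other groups, bromo and methoxy, not just from bromo. Compound 4 gives > 659000 nM, which is a limit and not a number. The step between the bromo and methoxy compounds cannot be read, as both values are limits, so these two groups stay unranked against each other.

On these data alone, compound 1 gives 119000 nM; 148000 nM (2 entries) with the same 4-methoxyphenyl but an ester in place of the carboxylic acid, so the true size of the effect of that one change stays open. Also open, as far as these compounds go, is whether a fluoro group or an amine at this place would stay close to compound 2 or reach a limit like compound 3 and compound 4.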